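This account rests on a few compounds, and the source may have more. Where it says the series, first, only, none or still open, it means among the compounds named here.

Measured so far: compound 1 `CCCCCCCCCCc1ccc(-c2noc(C3CCNC3)n2)cc1` and compound 2 `CCCCCCCCCCc1ccc(-c2noc(C3CCNCC3)n2)cc1`.

In an assay on HeLa cells for inhibition of sphingosine-1-phosphate transporter SPNS2 (Mus musculus), read by LC-MS, tested at 2 uM (a higher number here means more inhibition at the concentration tested (going by the name of the read-out), a lower number less inhibition), compound 1 gives 26%, and compound 2 gives 66%, the highest of the two numbers; the step of a number 40 percentage points higher from compound 1 to compound 2 (beyond the scatter) shows how far the amine-bearing group shapes this read-out. Compound 3 `CCCCCCCCCCc1ccc(-c2noc([C@@H](N)CCN)n2)cc1` differs from compound 2 by 1,3-diaminopropyl in place of piperidin-4-yl on an aromatic carbon. Within the data shown here, only that one step bears on the change, and it was large, so a large step is expected again, here downward. The estimate for compound 3 is 45%, with a range from 15% to 75%, meaning an expected step of a number 21 percentage points lower from compound 2 to compound 3 (beyond the scatter).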

Compound 3, a percentage reported as inhibition, at one concentration (the size of the read-out at that concentration, not a potency): 14%
Estimate against measurement, compound 3: 31 percentage points above; the whole stated range lies above it.
By their numbers in this assay, from the lowest: compound 3; then compound 1; then compound 2.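

In this assay, the open chain 1,3-diaminopropyl falls short of both ring groups at this position, with a number 52 percentage points lower from compound 2 to compound 3 (beyond the scatter) and a number 12 percentage points lower from compound 1 to compound 3 (beyond the scatter) in the two comparisons. This change removes the ring and also adds a second nitrogen, so these compounds cannot show which of the two matters. No measurement here explains the drop.

Open, as far as these compounds go, is how a 3-aminopropyl chain, with its single amine, would compare with the rings. Also open, from the compounds shown here alone, is where a smaller ring, azetidin-3-yl, would fall.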